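A few compounds are considered here, and "the series" means these few. Any claim that something is new, unique, unknown or untested is made for them only; others in the source may bear on it.

Among the measured compounds shown here, compound 2 `CN(C)C(=O)c1ccc(OCCCCC[C@H]2CC[C@]3(CCCO3)CC2)cc1` stands highest of the two numbers so far: in a functional assay on HEK293 cells for agonist activity at Glucose-dependent insulinotropic receptor (Homo sapiens), read by cAMP accumulation, with a stated time of 30 min (a lower number here means that less compound is needed, a higher number that more compound is needed for the effect), compound 2 gives 95 nM, whereas compound 1 `CN(C)C(=O)c1ccc(OCCCCC[C@H]2CC[C@]3(CCCCO3)CC2)cc1` gives 36 nM, a gap that lies beyond the scatter. Compound 3 `CN(C)C(=O)c1ccc(OCCCCC[C@H]2CC[C@@]3(CCCO3)CC2)cc1` remains to be measured. Relative to compound 2 the change is the two compounds have the same atoms and bonds and differ only in configuration as drawn: 2 of 2 stereo elements differ (all stereocentres are inverted: mirror images); a stereocentre at a saturated ring carbon is drawn s in compound 2 and r in compound 3; a stereocentre at a saturated ring carbon is drawn r in compound 2 and s in compound 3. For the measured compounds named here, no step between two measured compounds covers such an inversion, so the direction cannot be read from the series itself; mirror images may give values close together or far apart. Going by the values given here, compound 1 shares the drawn configuration of compound 2 and sits at the lower end of the numbers, which leaves the drawn configuration as the one with the better-supported value. On that basis the expected step is a 3.2-fold higher number from compound 2 to compound 3 (0.50 log units; beyond the scatter), towards a higher number. Compound 3 is therefore estimated at 300 nM, within a wide range from 50 nM to 3000 nM.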

Compound 3, half-maximal effective concentration: 132 nM
Beside the measured number, compound 3's estimate is 2.3-fold (0.36 log units) above it; the measured number falls inside the stated range.
By their numbers in this assay, from the lowest: compound 1; then compounds 2 and 3 (each within the scatter of the next).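

In this assay, inverting both stereocentres gives a 1.4-fold higher number from compound 2 to compound 3 (0.14 log units; within the scatter), so this mirror-image pair cannot be told apart by this read-out. Among the compounds shown here, this is the first direct reading of configuration: the two saturated ring carbons can both be inverted with no change beyond the scatter, and both mirror images remain active at comparable concentrations. The pair isolates configuration, with no group entering or leaving the comparison: the fact that compounds 2 and 3 differ only in the configuration as drawn

Going by these compounds, whether compound 1 and its mirror image would sit equally close stays open, as does the effect of inverting only one of the two stereocentres. On these data alone, it is also open whether configuration remains this unimportant when a carboxylic acid takes the place of the amide or a longer chain links the two ends of the molecule.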